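Ortho substitution on the N-aryl ring of the amide series

A few compounds are considered here, and "the series" means these few. Any claim that something is new, unique, unknown or untested is made for them only; others in the source may bear on it.

Measured so far:
compound 1 `COc1cc2c(Oc3ccc(NC(=O)c4cn(-c5ccccc5OC(F)(F)F)cn4)cc3F)ccnc2cc1OCCCN1CCCCC1` — 270 nM
compound 2 `COc1cc2c(Oc3ccc(NC(=O)c4cn(-c5ccc(Cl)cc5)cn4)cc3F)ccnc2cc1OCCCN1CCCCC1` — 6560 nM

Both compounds were run in a functional assay on A549 cells (Homo sapiens) for cytotoxicity, read by MTT assay, with a stated time of 72 h; a lower number here means a stronger inhibitor, a higher number a weaker inhibitor. Compound 2 stands at the highest of the two numbers; its nearest neighbour is compound 1, and the step of a 24-fold higher number from compound 1 to compound 2 (1.39 log units; beyond the scatter) is large and beyond the scatter.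

Compound 3 `COc1cc2c(Oc3ccc(NC(=O)c4cn(-c5ccc(Cl)cc5Cl)cn4)cc3F)ccnc2cc1OCCCN1CCCCC1` is not yet measured in this assay. It differs from compound 2 by chloro in place of hydrogen on an aromatic carbon, on an aromatic carbon of a six-membered aromatic ring of carbon only, ortho to a large group and meta to a chloro group; cut one bond further out, the change reads 4-chlorophenyl to 2,4-dichlorophenyl.

Going by the values given here, the only step that bears on this is a 24-fold higher number from compound 1 to compound 2 (1.39 log units; beyond the scatter), in which the ring bearing a group ortho to the attachment gave the far lower number. Compound 3 restores a substituent at that place, though a different one, so a lower number than compound 2 is expected in this assay, without a full return toward compound 1. The expected step is a 3.3-fold lower number from compound 2 to compound 3 (0.52 log units; beyond the scatter). For compound 3 the estimate is 2000 nM, with a range from 600 nM to 6500 nM.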

Compound 3, half-maximal inhibitory concentration: 7490 nM
Beside the measured number, compound 3's estimate is 3.7-fold (0.57 log units) below it, outside the stated range (above it).
By their numbers in this assay, from the lowest: compound 1; then compounds 2 and 3 (each within the scatter of the next).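

In this assay, chloro in place of hydrogen on the aromatic carbon ortho to a large group gives a 1.1-fold higher number from compound 2 to compound 3 (0.06 log units; within the scatter), so the change from 4-chlorophenyl to 2,4-dichlorophenyl does not separate these two compounds. A group at this place is therefore not enough on its own to bring the number toward that of compound 1: 2,4-dichlorophenyl in place of 2-(trifluoromethoxy)phenyl on the aromatic nitrogen goes with a 28-fold higher number from compound 1 to compound 3 (1.44 log units; beyond the scatter), and among the three compounds shown only the 2-(trifluoromethoxy)phenyl ring goes with a low number. No measurement on these compounds bears on the reason for this difference.

The compounds shown leave open whether the low number of compound 1 follows the trifluoromethoxy group itself or the absence of the chloro group carried by compound 2 and compound 3, a question that a 4-chloro-2-(trifluoromethoxy)phenyl ring would settle. Going by these compounds, it is also open how other groups at this place would read in this assay, such as a methoxy group or a dimethylamino group.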